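Removing a Hydroxy Group Ahead of a New Measurement

A few compounds are considered here, and "the series" means these few. Any claim that something is new, unique, unknown or untested is made for them only; others in the source may bear on it.

The compounds here were tested in a functional assay on MDA-MB-231 cells (Homo sapiens) for cytotoxicity, read by MTT assay; on this read-out higher numbers stand for weaker inhibition and lower numbers for stronger inhibition. Compound 1, `COc1ccc(-c2cn(-c3cc(OC)c(OC)c(OC)c3)nn2)cc1`, carries only methoxy groups on both outer rings. In this assay compound 1 reaches only the limit > 10000 nM rather than a number. Compound 2, `COc1ccc(-c2cn(-c3cc(OC)c(OC)c(OC)c3)nn2)cc1O`, adds a hydroxy group on one ring. In this assay compound 2 likewise stops at the limit > 10000 nM. The change from compound 2 to compound 1 is hydrogen in place of hydroxy on an aromatic carbon; its step that the two limits leave unreadable from compound 2 to compound 1 cannot be read, since both values are limits, as summarized by the limit of > 10000 nM in this assay, at which 2 of the 3 values shown sit. Compound 3, `COc1ccc(-c2cn(-c3ccc(OC)c(O)c3)nn2)cc1`, has a different core from compound 2, and that difference is not broken down here. In this assay compound 3 is reported only as the limit > 100 nM, which is the point described by the limit of > 100 nM in this assay, at which 1 of the 3 values shown sits.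

Compound 4, `COc1ccc(-c2cn(-c3ccc(OC)cc3)nn2)cc1`, is not yet measured. It differs from compound 3 by hydrogen in place of hydroxy on an aromatic carbon, the same change as from compound 2 to compound 1, with the same surroundings in both cases. Since that earlier step is unreadable and all three measured values are limits, the expectation rests on weak ground. The step from compound 3 to compound 4 in this assay is expected to be about a step that the limit leaves unreadable from compound 3 to compound 4. Compound 4 is estimated at 15000 nM, between 2000 nM and 60000 nM, with a strong chance of another limit.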

Compound 4, half-maximal inhibitory concentration: > 100 nM
Compound 4: only a limit was reported; the forecaster's own chance of this, stated with the estimate: 70%; the middle value is on the limit's open side.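

In this assay compound 3 and compound 4 are both reported only as limits rather than numbers, so the step between them cannot be read: the limit of > 100 nM in this assay, at which 2 of the 4 values shown sit.

The compounds shown leave open whether hydrogen in place of hydroxy on the aromatic carbon changes inhibition at all in this assay, and where the true value of each of the four compounds lies.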